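A few compounds are considered here, and "the series" means these few. Any claim that something is new, unique, unknown or untested is made for them only; others in the source may bear on it.

Values measured in a functional assay on MCF7 cells (Homo sapiens) for cytotoxicity, read by ELISA, with a stated time of 4 days; a higher number here means a weaker inhibitor, a lower number a stronger inhibitor:
- compound 1 `Cc1ccsc1-c1cc(-c2ccco2)cc(-c2ccc(Cl)cc2)n1`: 890 nM
- compound 2 `Cc1ccsc1-c1cc(-c2ccoc2)cc(-c2ccco2)n1`: 18300 nM
- compound 3 `Clc1ccc(-c2cc(-c3ccoc3)cc(-c3ccco3)n2)s1`: 4740 nM

Compound 3 holds the middle place of the three numbers, lower than compound 2 and higher than compound 1. Compound 4 `Cc1ccccc1-c1cc(-c2ccoc2)cc(-c2ccc(Cl)s2)n1` has not yet been measured. It differs from compound 3 as follows: 2-methylphenyl in place of furan-2-yl on an aromatic carbon.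

Going by the values given here, no measured step changes this furan-2-yl group alone. Among the compounds with values here, the one measured step, a 3.9-fold lower number from compound 2 to compound 3 (0.59 log units; beyond the scatter), is a modest one and concerns the 5-chlorothiophen-2-yl group elsewhere on the core. Compound 1 carries 4-chlorophenyl where compound 2 has furan-2-yl and shows a lower number than compound 2, but the two also differ in another place, so this is weak evidence. A modest move toward a lower number in this assay is therefore expected, though the direction is uncertain. The estimated change is a 1.6-fold lower number from compound 3 to compound 4 (0.20 log units; within the scatter) and could lie within the scatter. Compound 4 is expected at about 3000 nM, with an estimated range of 800 nM to 10000 nM as the likely span.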

Compound 4, half-maximal inhibitory concentration: 1430 nM
For compound 4 the middle estimate is 2.1-fold (0.32 log units) above the measured one, within the range that was stated.
By their numbers in this assay, from the lowest: compounds 1 and 4 (each within the scatter of the next); then compound 3; then compound 2.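

In this assay, 2-methylphenyl in place of furan-2-yl on the aromatic carbon next to the ring nitrogen gives a 3.3-fold lower number from compound 3 to compound 4 (0.52 log units; beyond the scatter), and this is the only step shown that changes this position alone. In this pair, the position accepts a six-membered aromatic ring of carbon only in place of a five-membered aromatic ring with 1 hetero atom, and the number falls rather than rises. Nothing measured here bears on what lies behind this step.

Going by these compounds, whether the lower number comes from the six-membered ring itself or from its methyl group stays open, and a plain phenyl group at this position would separate the two. Also open, on these data alone, is how an amine or a carboxylic acid on this ring would read in this assay, and whether the same change holds with another group in place of 5-chlorothiophen-2-yl.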